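Swapping the trimethoxyphenyl of compound 2 for bromophenyl

The source may report more compounds than this note shows. Statements on the series, on what has been measured and on what is new or still open speak of the compounds shown alone.

Three measured compounds share one core and differ only in the aryl group on the amino nitrogen. Compound 1 `COc1cc(-c2nc(SCc3cn(CC(=O)NC(=O)Nc4ccccn4)nn3)nc(Nc3ccc(C(C)C)cc3)c2C#N)cc(OC)c1OC` gives 1210 nM in a functional assay on B16-F10 cells (Mus musculus) for inhibition, read by MTT assay, with a stated time of 72 h; a lower number here means a stronger inhibitor, a higher number a weaker inhibitor. Compound 2 `COc1cc(-c2nc(SCc3cn(CC(=O)NC(=O)Nc4ccccn4)nn3)nc(Nc3ccc(C)cc3)c2C#N)cc(OC)c1OC` gives 32 nM in this assay, and compound 3 `COc1cc(-c2nc(SCc3cn(CC(=O)NC(=O)Nc4ccccn4)nn3)nc(Nc3cccc(Cl)c3)c2C#N)cc(OC)c1OC` gives 1420 nM. Compound 2 holds the lowest number of the three: the step of a 38-fold lower number from compound 1 to compound 2 (1.58 log units; beyond the scatter) and the step of a 44-fold higher number from compound 2 to compound 3 (1.65 log units; beyond the scatter) both lie beyond the scatter, whereas a 1.2-fold higher number from compound 1 to compound 3 (0.07 log units; within the scatter).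

Compound 4 `Cc1ccc(Nc2nc(SCc3cn(CC(=O)NC(=O)Nc4ccccn4)nn3)nc(-c3ccc(Br)cc3)c2C#N)cc1` is not yet measured. It keeps the (4-methylphenyl)amino group of compound 2 and differs from it in one place: 4-bromophenyl in place of 3,4,5-trimethoxyphenyl on an aromatic carbon. Within the data shown here, none of the measured steps touches this place; all three vary the aryl group on the nitrogen. The measured set therefore says nothing about how the 3,4,5-trimethoxyphenyl ring bears on the number, and an expectation for compound 4 can rest only on compound 2 standing at the low end with 32 nM and on the change being a sizeable one elsewhere on the core. Compound 4 is expected to give about 400 nM, somewhere between 50 nM and 4000 nM, which amounts to an expected step of a 13-fold higher number from compound 2 to compound 4 (1.10 log units; beyond the scatter) in this assay.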

Compound 4, half-maximal inhibitory concentration: 8160 nM
Compound 4: middle estimate off by 20-fold (1.31 log units), on the low side, and the stated range ends below it.
By their numbers in this assay, from the lowest: compound 2; then compounds 1 and 3 (each within the scatter of the next); then compound 4.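

Among these compounds, the earlier compounds varied only the aryl group on the amino nitrogen, so this is the first reading at the aromatic carbon next to the ring nitrogen: with the (4-methylphenyl)amino group kept, 4-bromophenyl in place of 3,4,5-trimethoxyphenyl gives a 260-fold higher number from compound 2 to compound 4 (2.41 log units; beyond the scatter) in this assay. The number therefore depends strongly on the group at this carbon as well as on the aryl group on the nitrogen, although this rests on a single pair. The change alters several things at once, from 12 heavy atoms to 7 and from 3 hydrogen-bond acceptors to 0, and nothing available here explains the rise or assigns it to any one of them.

Going by these compounds, it remains open whether the rise follows from losing the methoxy groups or from gaining the bromine, a question that a plain phenyl or a methoxyphenyl at this carbon would help to separate. On these data alone, it is also open whether a step of this size would recur with 4-isopropylphenyl or 3-chlorophenyl on the nitrogen.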